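Cyclopropyl for methyl at the carbinol carbon

The source may hold more compounds than are shown below. What is called first, only, known or untested is meant among the compounds shown, and "the series" means these compounds.

Within the data shown here, the two compounds measured so far share a biaryl carbinol bearing an imidazole. Compound 1 `CNS(=O)(=O)c1cccc(-c2ccc(C(O)(c3c[nH]cn3)C(C)C)cc2)c1` gives 160 nM in an assay on isolated protein for inhibition of steroid 17-alpha-hydroxylase/17,20 lyase (Homo sapiens); on this read-out lower numbers stand for stronger inhibition and higher numbers for weaker inhibition. Compound 2 `CC(=O)Nc1cccc(-c2ccc(C(C)(O)c3c[nH]cn3)cc2)c1` gives 38 nM in this assay, the lowest of the two numbers, and the gap to compound 1 lies beyond the scatter. Among the measured compounds shown here, compound 2 and compound 1 differ in more than one place, so the two values show only that compound 2 inhibits more strongly.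

Compound 3 `CC(=O)Nc1cccc(-c2ccc(C(O)(c3c[nH]cn3)C3CC3)cc2)c1` is drawn from compound 2 by one change: cyclopropyl in place of methyl on a saturated chain carbon bound to two aromatic carbons and an oxygen on a saturated carbon. For the measured compounds named here, no measured pair shows this change, so the size and direction of its effect are unknown. The step from compound 2 to compound 3 in this assay is expected to be small, a 1.1-fold higher number from compound 2 to compound 3 (0.02 log units; within the scatter), likely within the scatter. Compound 3 is therefore estimated at 40 nM, with a range from 12 nM to 130 nM.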

Compound 3, half-maximal inhibitory concentration: 45 nM
Compound 3: middle estimate off by 1.1-fold (0.05 log units), on the low side, and the stated range covers the measured number.
By their numbers in this assay, from the lowest: compounds 2 and 3 (each within the scatter of the next); then compound 1.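

Putting cyclopropyl in place of methyl on a saturated chain carbon bound to two aromatic carbons and an oxygen on a saturated carbon gives a 1.2-fold higher number from compound 2 to compound 3 (0.07 log units; within the scatter) in this assay. Among these compounds, this is the first pair that differs in one place, and it shows that, with the rest of compound 2 held fixed, this position takes the three-membered ring of cyclopropyl in place of methyl without a difference beyond the scatter. The data shown offer no measurement that would explain this result.

From the compounds shown here alone, how this position responds to a longer chain, a phenyl ring or an amine remains open. So does whether the same exchange reads alike when the acetamide shared by compound 2 and compound 3 gives way to the sulfonamide of compound 1.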